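Acylurea Hydrazones on A549 Cells: Nitro Replaces Trifluoromethyl

This account rests on a few compounds, and the source may have more. Where it says the series, first, only, none or still open, it means among the compounds named here.

Compound 1: `CN(C(=O)NC(=O)c1ccc(Cl)cc1Cl)c1nc(C(F)(F)F)c(C(=O)N/N=C/c2cccc(C(F)(F)F)c2)s1`, 10.6 ug/mL
Compound 2: `CN(C(=O)NC(=O)c1ccc(C(F)(F)F)cc1)c1nc(C(F)(F)F)c(C(=O)N/N=C/c2cccc(C(F)(F)F)c2)s1`, 6.66 ug/mL

Two compounds share one core and differ only in the aryl group on the acylurea carbonyl. In a functional assay on A549 cells (Homo sapiens) for inhibition, read by MTT assay, with a stated time of 72 h (a higher number here means a weaker inhibitor, a lower number a stronger inhibitor), compound 1 gives 10.6 ug/mL, and compound 2 gives 6.66 ug/mL. Among the measured compounds shown here, the single measured step, a 1.6-fold lower number from compound 1 to compound 2 (0.20 log units; within the scatter), is within the scatter, so compound 2 stands beside compound 1, the only other number, without being separable from it.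

Compound 3, `CN(C(=O)NC(=O)c1ccc([N+](=O)[O-])cc1)c1nc(C(F)(F)F)c(C(=O)N/N=C/c2cccc(C(F)(F)F)c2)s1`, is not yet measured. It arises from compound 2 by nitro in place of trifluoromethyl on an aromatic carbon. For the measured compounds named here, only the one step bears on this change, and that swap of the aryl group on a carbonyl carbon gave no resolved difference. Compound 3 is therefore expected to land near compound 2, with a change of a 1.1-fold higher number from compound 2 to compound 3 (0.05 log units; within the scatter) expected to stay within the scatter. The estimate for compound 3 in this assay is 7.5 ug/mL, with a range from 3.5 ug/mL to 16 ug/mL.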

Compound 3, half-maximal inhibitory concentration: 5.42 ug/mL
The estimate for compound 3 lay 1.4-fold (0.14 log units) above the measured number; measured number inside the range.
By their numbers in this assay, from the lowest: compounds 3, 2 and 1 (each within the scatter of the next).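

In this assay the exchange at this single place, on an aromatic carbon para to a large group, is nitro in place of trifluoromethyl, and with a 1.2-fold lower number from compound 2 to compound 3 (0.09 log units; within the scatter) the two groups are not separated. The earlier compounds shown here had compared only 2,4-dichlorophenyl with 4-(trifluoromethyl)phenyl; with a 2.0-fold lower number from compound 1 to compound 3 (0.29 log units; within the scatter) the 4-nitrophenyl group also stays unresolved from 2,4-dichlorophenyl, so all three aryl groups on the carbonyl carbon remain within the scatter of one another. No measurement is available that would explain these numbers.

The compounds shown leave open whether an amine or a carboxylic acid on this aromatic carbon would move the number beyond the scatter. They also leave open what the rest of the shared core contributes, as all three compounds carry it unchanged.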